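Swapping a halogenated phenyl ring on a piperazine

This account rests on a few compounds, and the source may have more. Where it says the series, first, only, none or still open, it means among the compounds named here.

Three compounds were tested in a functional assay on the whole organism (Abdomen, strain Swiss) for inhibition, with Mus musculus as the target, with stated times of 30 min, 10 min and 5 min, at a dose of 20 mg/kg by the oral route; a lower number here means a weaker effect, a higher number a stronger effect of the compound at the dose given. Compound 1 `CC(=O)c1cccn1CCCN1CCN(c2ccc(F)cc2)CC1` gives 16%, and compound 2 `CC(=O)c1cccn1CCCN1CCN(c2cccc(Cl)c2)CC1` gives 41%. The change between them, (3-chlorophenyl in place of 4-fluorophenyl on an amine nitrogen in a ring), produced a number 25 percentage points higher from compound 1 to compound 2 (beyond the scatter). Compound 3 `O=c1occ(-c2ccccc2)n1CCCN1CCN(c2ccc(F)cc2)CC1` gives 12%, a number that sits within the usual scatter of the value for compound 1; how the core of compound 3 differs from the core of compound 1 is not broken down here. Compound 4 `O=c1occ(-c2ccccc2)n1CCCN1CCN(c2cccc(Cl)c2)CC1` has not yet been measured in this assay and carries the same change, (3-chlorophenyl in place of 4-fluorophenyl on an amine nitrogen in a ring), on the same place. For compound 4 the step is estimated at a number 23 percentage points higher from compound 3 to compound 4 (beyond the scatter) because the same change gave a number 25 percentage points higher from compound 1 to compound 2 (beyond the scatter), although a single earlier example is thin ground. Compound 4 is therefore expected to show about 35%, likely between 18% and 52%.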

Compound 4, a percentage reported as inhibition, in the whole organism at one dose (the size of the read-out at that dose, not a potency): 31%
Estimate against measurement, compound 4: 4 percentage points above; low and high end bracket the measured number.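

In this assay, putting 3-chlorophenyl in place of 4-fluorophenyl on the second core gave a number 19 percentage points higher from compound 3 to compound 4 (beyond the scatter), so the change also raised the read-out there. The size of the step held up from one core to the other: the same change on two cores in this assay, a number 25 percentage points higher (beyond the scatter) from compound 1 to compound 2 and a number 19 percentage points higher (beyond the scatter) from compound 3 to compound 4, 6 percentage points apart, within the scatter of two such steps. For the compounds shown here, this rests on only two cores and one pair of groups at a single dose, so it does not show that the change would carry over to other cores, nor whether the kind of halogen or its place on the phenyl ring matters.

The compounds shown leave open how 4-chlorophenyl or 3-fluorophenyl would compare, which would help separate those two differences. From the compounds shown here alone, a plain phenyl or a longer chain also remains open.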